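A few compounds are considered here, and "the series" means these few. Any claim that something is new, unique, unknown or untested is made for them only; others in the source may bear on it.

Working notes on the series.

Three members of the series have been measured in a functional assay on DU-145 cells (Homo sapiens) for inhibition, read by trypan blue exclusion, with a stated time of 96 h; on this read-out lower numbers stand for stronger inhibition of growth and higher numbers for weaker inhibition of growth. Compound 1 `COc1ccc(/C=C(/SCc2ccc(Cl)cc2)C(=O)c2ccc(Br)cc2)cc1` gives 10000 nM. Compound 2 `O=C(/C(=C\c1ccc(Cl)cc1)SCc1ccc(Cl)cc1)c1ccc(Br)cc1` gives 10000 nM. Compound 3 `O=C(/C(=C\c1cccc(Cl)c1Cl)SCc1ccc(Cl)cc1)c1ccc(Br)cc1` gives 10000 nM. The three values stand level at the digits shown. The step from compound 1 to compound 2 is no change at the digits printed from compound 1 to compound 2 (within the scatter), the step from compound 1 to compound 3 is no change at the digits printed from compound 1 to compound 3 (within the scatter), and the step from compound 2 to compound 3 is no change at the digits printed from compound 2 to compound 3 (within the scatter). Within the data shown here, compound 3 therefore stands level with compound 1 and compound 2 in this assay, with no measured step that moves the read-out beyond the scatter.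

Compound 4 `COc1ccccc1/C=C(/SCc1ccc(Cl)cc1)C(=O)c1ccc(Br)cc1` differs from compound 3 as follows: 2-methoxyphenyl in place of 2,3-dichlorophenyl on a double-bonded chain carbon bound to a double-bonded chain carbon. The same position has already carried 4-methoxyphenyl, 4-chlorophenyl and 2,3-dichlorophenyl, and the steps among those three were all flat. The step from compound 3 to compound 4 is expected to be flat as well, no change at the digits printed from compound 3 to compound 4 (within the scatter), because of no change at the digits printed from compound 1 to compound 3 (within the scatter) and no change at the digits printed from compound 2 to compound 3 (within the scatter).

Compound 4 is expected to give 10000 nM in this assay, within 5000 nM to 20000 nM.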

Compound 4, concentration for 50% growth inhibition: 1000 nM
Estimate against measurement, compound 4: 10-fold (1.00 log units) above; measured number outside the range, below it.
By their numbers in this assay, from the lowest: compound 4; then compounds 1, 2 and 3 (each within the scatter of the next).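

In this assay this position, on a double-bonded chain carbon bound to a double-bonded chain carbon, is no longer flat: 2-methoxyphenyl gives a 10-fold lower number from compound 3 to compound 4 (1.00 log units; beyond the scatter) and a 10-fold lower number from compound 2 to compound 4 (1.00 log units; beyond the scatter), which makes compound 4 the strongest growth inhibitor of the four. The closest comparison keeps the methoxy group and changes only the aryl group's substitution, from 4-methoxyphenyl to 2-methoxyphenyl, and still gives a 10-fold lower number from compound 1 to compound 4 (1.00 log units; beyond the scatter), so the presence of a methoxy group alone does not carry the gain, and the 2,3-dichlorophenyl of compound 3 shows that substitution at the 2 position of the ring does not carry it either. Nothing at hand bears on why this change lowers the number.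

What the compounds shown leave open is whether the gain needs the methoxy group itself, or whether an amine or a longer ether chain in its place would hold it. They also leave open whether 2-methoxyphenyl keeps its effect when the bromine or the 4-chlorobenzyl group on sulfur of the shared core is replaced, for instance by a carboxylic acid or an unsubstituted benzyl group.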